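Second fluorine on the nitrile analogue: an estimate

The source may report more compounds than this note shows. Statements on the series, on what has been measured and on what is new or still open speak of the compounds shown alone.

Three compounds sharing one core have been run in a functional assay on the whole organism (strain Swiss albino) for inhibition, with Mus musculus as the target, in the writhing test, with a stated time of 30 min, at a dose of 5 mg/kg by the oral route; on this read-out higher numbers stand for a stronger effect at the one dose given and lower numbers for a weaker effect. Compound 1 `Cc1c(C=O)cc(-c2ccc(S(C)(=O)=O)cc2)n1-c1ccc(F)c(F)c1` gives 50% in this assay. Within the data shown here, compound 2 `Cc1c(/C=N\O)cc(-c2ccc(S(C)(=O)=O)cc2)n1-c1ccc(F)c(F)c1` gives 10% in this assay, and the step of a number 40 percentage points lower from compound 1 to compound 2 (beyond the scatter) is the only single-change step measured. Compound 3 `Cc1c(C#N)cc(-c2ccc(S(C)(=O)=O)cc2)n1-c1cccc(F)c1` gives 21% in this assay, which places it second highest of the three numbers: it lies beyond the scatter above compound 2 and beyond the scatter below compound 1.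

Compound 4 `Cc1c(C#N)cc(-c2ccc(S(C)(=O)=O)cc2)n1-c1ccc(F)c(F)c1` has not yet been measured. It differs from compound 3 by fluoro in place of hydrogen on an aromatic carbon, which read one bond further out is 3-fluorophenyl to 3,4-difluorophenyl. Among the measured compounds shown here, no measured step follows this change; the step from compound 1 to compound 2 concerns a different part of the molecule, and compound 1 and compound 3 differ in two places at once, so their values show only that both carry fluorine and differ in the group on the core. For the measured compounds named here, with no direct precedent, the step of a number 4 percentage points higher from compound 3 to compound 4 (within the scatter) is expected to stay small, around the scatter. Compound 4 is therefore estimated to give 25% in this assay, within a range from 8% to 45%.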

Compound 4, a percentage reported as inhibition, in the whole organism at one dose (the size of the read-out at that dose, not a potency): 8%
Compound 4: middle estimate off by 17 percentage points, on the high side, within the range that was stated.
By their numbers in this assay, from the lowest: compounds 4 and 2 (each within the scatter of the next); then compound 3; then compound 1.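

In this assay, the fluoro group on the aromatic carbon ortho to a fluoro group and para to a large group is not neutral: going from 3-fluorophenyl to 3,4-difluorophenyl gives a number 13 percentage points lower from compound 3 to compound 4 (beyond the scatter) and so the nitrile series does not hold its read-out with the second fluorine. With 3,4-difluorophenyl held constant, cyano in place of formyl gives a number 42 percentage points lower from compound 1 to compound 4 (beyond the scatter) while cyano in place of the group on the core of compound 2 gives a number 2 percentage points lower from compound 2 to compound 4 (within the scatter) and so formyl alone stands apart among these three groups. Nothing available here explains these steps. As far as these compounds go, whether the fluoro step would carry over with formyl on the core remains open. So does the outcome with chloro or methoxy on that aromatic carbon, or with a carboxylic acid on the core.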